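This account rests on a few compounds, and the source may have more. Where it says the series, first, only, none or still open, it means among the compounds named here.

Measured so far in a functional assay on PC-3 cells (Homo sapiens) for inhibition; a higher number here means a weaker inhibitor, a lower number a stronger inhibitor:
compound 1 `Cc1c(C(=O)N/N=C\c2ccc(O)cc2)oc2cccc(O)c12` — 21700 nM
compound 2 `Cc1c(C(=O)N/N=C\c2cccc(F)c2O)oc2cccc(O)c12` — 12700 nM
compound 3 `Cc1c(C(=O)N/N=C\c2cc(O)ccc2O)oc2cccc(O)c12` — 95500 nM

Compound 1 sits second highest of the three numbers; compound 2 lies nearest, a 1.7-fold lower number from compound 1 to compound 2 (0.23 log units; within the scatter), while compound 3 lies furthest, a 4.4-fold higher number from compound 1 to compound 3 (0.64 log units; beyond the scatter). Compound 4 `Cc1c(C(=O)N/N=C\c2ccc(C(F)(F)F)cc2)oc2cccc(O)c12` has not been measured. It differs from compound 1 by trifluoromethyl in place of hydroxy on an aromatic carbon. Within the data shown here, no measured step replaces a hydroxy with a trifluoromethyl; the steps to compound 2 and compound 3 exchange the whole aryl group on the carbon with a double bond to nitrogen, and the step between them, a 7.5-fold higher number from compound 2 to compound 3 (0.88 log units; beyond the scatter), shows such exchanges moving the number only modestly. No shown step bears directly on the change to compound 4, so the expected step of a 1.2-fold higher number from compound 1 to compound 4 (0.06 log units; within the scatter) in this assay carries wide uncertainty. Compound 4 is estimated at 25000 nM, range 8000 nM to 80000 nM.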

Compound 4, half-maximal inhibitory concentration: >= 40000 nM
Compound 4 was reported as a limit; the forecaster's own chance of this, stated with the estimate: 15%; middle value at least 1.6-fold (0.20 log units) from the limit.
By their numbers in this assay, from the lowest: compounds 2 and 1 (each within the scatter of the next); then compound 3.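

In this assay, compound 4 is reported only as a limit: the limit of >= 40000 nM in this assay, at which 1 of the 4 values shown sits.

Trifluoromethyl in place of hydroxy on this aromatic carbon, para to a large group, gives an at least 1.8-fold higher number from compound 1 to compound 4 (0.26 log units; that floor lies within the scatter), the first step shown that changes only this substituent. The step shows no gain in inhibition from this exchange, although its floor does not establish a loss.

From the compounds shown here alone, it remains open whether removing the hydroxy or adding the trifluoromethyl governs the outcome. Going by these compounds, how an amine, a methoxy or a carboxylic acid would read at this position also remains open.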